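A few compounds are considered here, and "the series" means these few. Any claim that something is new, unique, unknown or untested is made for them only; others in the source may bear on it.

Compound 1, `CNCc1cc(-c2cccnc2F)n(S(=O)(=O)c2cccc(OC)c2)c1`: 92%
Compound 2, `CNCc1cc(-c2cccnc2F)n(S(=O)(=O)c2cccc(C#N)c2)c1`: 99%
Compound 3, `CNCc1cc(-c2cccnc2F)n(S(=O)(=O)c2ccsc2)c1`: 98%

All three compounds were tested in a functional assay on the whole organism (strain Jcl:SD) for inhibition, with Rattus norvegicus as the target, with stated times of 3 min and 3 h, at a dose of 1 mg/kg by the intravenous route; a higher number here means more inhibition at the dose given (going by the name of the read-out), a lower number less inhibition. Compound 3 stands second highest of the three numbers, though its neighbours are close: the step of a number 1 percentage points lower from compound 2 to compound 3 (within the scatter) and the step of a number 6 percentage points higher from compound 1 to compound 3 (within the scatter) both lie within the usual scatter, so the three compounds cannot be told apart on these numbers.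

Compound 4, `CNCc1cc(-c2cccnc2F)n(S(=O)(=O)c2cccs2)c1`, has not yet been measured. It differs from compound 3 in one place: thiophen-2-yl in place of thiophen-3-yl on a sulfonyl sulfur. The group on the sulfonyl sulfur is rearranged, the same atoms joined differently.

Among the compounds with values here, no measured step swaps one thiophenyl for another. Within the data shown here, the steps that bear on this change are those that alter the group on the sulfonyl sulfur, a number 6 percentage points higher from compound 1 to compound 3 (within the scatter) and a number 1 percentage points lower from compound 2 to compound 3 (within the scatter), and also a number 7 percentage points higher from compound 1 to compound 2 (within the scatter); every one of them stays within the scatter. Three different groups at this position all gave high inhibition in this assay, so a fourth variation is expected to do the same, with no step beyond the scatter in either direction.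

Compound 4 is therefore estimated at 96% in this assay, within a range of 86% to 100%. The expected step is a number 2 percentage points lower from compound 3 to compound 4 (within the scatter).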

Compound 4, a percentage reported as inhibition, in the whole organism at one dose (the size of the read-out at that dose, not a potency): 96%
For compound 4 middle estimate and measured number coincide at the digits printed, within the range that was stated.
By their numbers in this assay, from the lowest: compounds 1, 4, 3 and 2 (each within the scatter of the next).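

Joining the same five-membered aromatic ring to the sulfonyl sulfur through a different atom gives a number 2 percentage points lower from compound 3 to compound 4 (within the scatter) in this assay, so the position shows no sensitivity to this rearrangement in these numbers. The steps from the two compounds with substituted phenyl groups, a number 3 percentage points lower from compound 2 to compound 4 (within the scatter) and a number 4 percentage points higher from compound 1 to compound 4 (within the scatter), also stay within the scatter, which means that thiophen-2-yl cannot be told apart from 3-cyanophenyl or 3-methoxyphenyl here, and all four groups on the sulfonyl sulfur give similar inhibition at this single dose. No measurement shown offers an explanation for this similarity.

All four numbers lie near the top of the percentage scale, so these compounds leave open whether they would separate at a lower dose, where the read-out would have more room to differ. They also leave open whether a quite different group on the sulfonyl sulfur, such as a small methyl, or a phenyl carrying a carboxylic acid or an amine, would give inhibition at this same level.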